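The source may report more compounds than this note shows. Statements on the series, on what has been measured and on what is new or still open speak of the compounds shown alone.

Compound 1 `C=CCn1c(=O)/c(=C\c2cccc(F)c2)[nH]c(=O)/c1=C\c1ccccc1OC`: 4100 nM
Compound 2 `COc1ccccc1/C=c1\c(=O)[nH]/c(=C/c2ccccc2Cl)c(=O)n1C`: 110 nM
Compound 3 `C=CCn1c(=O)/c(=C\c2ccccc2F)[nH]c(=O)/c1=C\c1ccccc1OC`: 5600 nM

In a functional assay on K562 cells (Homo sapiens) for cytotoxicity, read by CCK-8 assay, with a stated time of 72 h (on this read-out lower numbers stand for stronger inhibition and higher numbers for weaker inhibition), compound 3 gives the highest number of the three measured. Compound 1 is nearest to it, and the step of a 1.4-fold higher number from compound 1 to compound 3 (0.14 log units; within the scatter) is within the scatter, so the two cannot be ordered. Compound 2 gives 110 nM; its gap to compound 3 is well beyond the scatter, but compound 2 differs from compound 3 in two places, a chlorine-bearing ring and a methyl on the shared core, so no single step can be read from that pair.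

Compound 4 `C=CCn1c(=O)/c(=C\c2ccccc2Cl)[nH]c(=O)/c1=C\c1ccccc1OC` differs from compound 3 by chloro in place of fluoro on an aromatic carbon, on an aromatic carbon of a six-membered aromatic ring of carbon only, ortho to a large group. Within the data shown here, no measured step isolates this exchange; the only single-place step, a 1.4-fold higher number from compound 1 to compound 3 (0.14 log units; within the scatter), moves the fluorine and is within the scatter. The low number of compound 2 hints that chlorine at this position may lower the number, though its methyl on the core confounds the reading. For compound 4 a modest lowering is therefore expected, a 2.2-fold lower number from compound 3 to compound 4 (0.35 log units; beyond the scatter), with a wide range. Compound 4 is estimated at 2500 nM, between 700 nM and 8000 nM.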

Compound 4, half-maximal inhibitory concentration: 2500 nM
Estimate against measurement, compound 4: no gap at the digits printed; the measured number falls inside the stated range.
By their numbers in this assay, from the lowest: compound 2; then compounds 4, 1 and 3 (each within the scatter of the next, the first and the last beyond it).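

In this assay, chloro in place of fluoro on the aromatic carbon ortho to a large group gives a 2.2-fold lower number from compound 3 to compound 4 (0.35 log units; beyond the scatter), so this exchange has a modest but readable effect, which the fluorine move alone did not show. Against the 3-fluorophenyl group, the 2-chlorophenyl group gives a 1.6-fold lower number from compound 1 to compound 4 (0.21 log units; within the scatter), which leaves those two compounds unordered. The larger change lies at the other place: vinyl in place of hydrogen on the saturated chain carbon bound to the aromatic nitrogen gives a 23-fold higher number from compound 2 to compound 4 (1.36 log units; beyond the scatter), so the low number of compound 2 goes with that place and not with its chlorine.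

Still open, from the compounds shown here alone, is how a longer saturated chain, or a chain ending in an amine, would read at that carbon, and whether bromo would extend the chloro step. Nothing available explains either step.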